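A few compounds are considered here, and "the series" means these few. Any claim that something is new, unique, unknown or untested is made for them only; others in the source may bear on it.

Compound 1: `CC(=O)c1cc2ccc(OCCCn3cc(CNC(=O)CCCCC4CCSS4)nn3)cc2oc1=O` — 39.8%
Compound 2: `O=C(CCCCC1CCSS1)NCc1cn(CCCOc2ccc3cc(-c4ccc(Br)cc4)c(=O)oc3c2)nn1` — 69.1%

Among the measured compounds shown here, in a functional assay on PC-12 cells (Rattus norvegicus) for cytotoxicity, read by MTT assay, with stated times of 3 h and 2 h, tested at 20 uM (on this read-out higher numbers stand for a stronger effect at the one concentration tested and lower numbers for a weaker effect), compound 2 gives 69.1%, the higher of the two numbers measured so far. Its nearest neighbour is compound 1, which in this assay gives 39.8%. For the measured compounds named here, the only measured step, a number 29.3 percentage points higher from compound 1 to compound 2 (beyond the scatter), is beyond the scatter and of modest size; it comes with 4-bromophenyl in place of acetyl on an aromatic carbon.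

Compound 3, `O=C(CCCCC1CCSS1)NCc1cn(CCCOc2ccc3cc(-c4ccc(Cl)cc4)c(=O)oc3c2)nn1`, differs from compound 2 in one place: chloro in place of bromo on an aromatic carbon. Going by the values given here, no measured step bears directly on this change, since the one step, a number 29.3 percentage points higher from compound 1 to compound 2 (beyond the scatter), replaces a whole acetyl group by a 4-bromophenyl and says nothing about one halogen against another on that ring. With nothing to point either way, the expected step of a number 4.1 percentage points lower from compound 2 to compound 3 (within the scatter) is none beyond the scatter, with compound 3 expected to stay near compound 2. Compound 3 is therefore estimated at 65%, in a range from 45% to 82%.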

Compound 3, a percentage reported as activity, at one concentration (the size of the read-out at that concentration, not a potency): 75.6%
For compound 3 the middle estimate is 10.6 percentage points below the measured one; measured number inside the range.
By their numbers in this assay, from the lowest: compound 1; then compounds 2 and 3 (each within the scatter of the next).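

In this assay, chloro in place of bromo on an aromatic carbon, para to a large group, gives a number 6.5 percentage points higher from compound 2 to compound 3 (within the scatter), so at this place the read-out does not tell the two halogens apart. The step of a number 35.8 percentage points higher from compound 1 to compound 3 (beyond the scatter), with 4-chlorophenyl in place of acetyl, points the same way as a number 29.3 percentage points higher from compound 1 to compound 2 (beyond the scatter), so the gain over the acetyl group of compound 1 is now seen with two different halogens and does not rest on bromo alone. No measurement shown here offers a reason for either step.

The compounds shown leave open whether a halogen is needed at all, since a plain phenyl group, or a methoxy group or an amine in place of the halogen on that ring, could give a number like those of compound 2 and compound 3 or a quite different one. They also leave open what a longer chain would do in place of the one joining the shared core to the rest of the molecule, and, with each number taken at a single concentration, how these compounds compare across a range of concentrations.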